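Thiophenylmethyl Amide After Three Flat Heteroaryl Amide Steps

The source may report more compounds than this note shows. Statements on the series, on what has been measured and on what is new or still open speak of the compounds shown alone.

Compound 1 `CCCOc1cc(C)c2c(c1C)C[C@H]([C@@H](C)C(=O)Nc1ccccn1)CC2`: 900 nM
Compound 2 `CCCOc1cc(C)c2c(c1C)C[C@H]([C@@H](C)C(=O)Nc1nccs1)CC2`: 800 nM
Compound 3 `CCCOc1cc(C)c2c(c1C)C[C@H]([C@@H](C)C(=O)Nc1ncc(C)s1)CC2`: 1000 nM

Three amides on a shared core have been measured in an assay on cells for inhibition of Polyunsaturated fatty acid 5-lipoxygenase (Homo sapiens); on this read-out higher numbers stand for weaker inhibition and lower numbers for stronger inhibition. Compound 3 gives the highest of the three numbers, but it is separated from the others only by the step of a 1.1-fold higher number from compound 1 to compound 3 (0.05 log units; within the scatter) and the step of a 1.3-fold higher number from compound 2 to compound 3 (0.10 log units; within the scatter), so no order among the three can be read. Compound 4 `CCCOc1cc(C)c2c(c1C)C[C@H]([C@@H](C)C(=O)NCc1cccs1)CC2` differs from compound 3 by (thiophen-2-yl)methyl in place of 5-methyl-1,3-thiazol-2-yl on an amide-type nitrogen. The measured steps of a 1.1-fold lower number from compound 1 to compound 2 (0.05 log units; within the scatter), a 1.1-fold higher number from compound 1 to compound 3 (0.05 log units; within the scatter) and a 1.3-fold higher number from compound 2 to compound 3 (0.10 log units; within the scatter) each exchange one aromatic ring for another attached directly to the amide-type nitrogen, and all stayed within the scatter; none inserts a methylene between the nitrogen and the ring, so they bear on this change only loosely. The expectation is therefore a step of a 1.5-fold higher number from compound 3 to compound 4 (0.18 log units; within the scatter) in this assay, a mild weakening that may still fall within the scatter. Compound 4 is estimated at 1500 nM, with a range from 500 nM to 5000 nM.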

Compound 4, half-maximal inhibitory concentration: 8000 nM
Compound 4: the middle estimate sits 5.3-fold (0.73 log units) below what was measured, and the stated range ends below it.
By their numbers in this assay, from the lowest: compounds 2, 1 and 3 (each within the scatter of the next); then compound 4.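

In this assay, the aromatic rings attached directly to the amide-type nitrogen had stayed within the scatter of one another, but (thiophen-2-yl)methyl at this place gives an 8.0-fold higher number from compound 3 to compound 4 (0.90 log units; beyond the scatter), a 10-fold higher number from compound 2 to compound 4 (1.00 log units; beyond the scatter) and an 8.9-fold higher number from compound 1 to compound 4 (0.95 log units; beyond the scatter), all beyond the scatter. The position that had shown no response to exchanging one directly attached ring for another therefore does respond to this change, and all three steps point the same way, to weaker inhibition. No measurement here accounts for this weakening.

The change replaces the ring and adds the methyl link together, so compound 4 alone cannot show which of the two carries the step. Going by these compounds, a thiophen-2-yl group directly on the amide-type nitrogen and a (1,3-thiazol-2-yl)methyl group there remain open, as do a benzyl group and the longer 2-(thiophen-2-yl)ethyl chain.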